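Paw edema series: chloro on the aryl of compound 3

The source may report more compounds than this note shows. Statements on the series, on what has been measured and on what is new or still open speak of the compounds shown alone.

Measured so far in a functional assay on the whole organism (strain albino) for inhibition, with Rattus norvegicus as the target, read by paw edema, with stated times of 30 min and 2 h, at a dose of 50 mg/kg by the oral route; on this read-out lower numbers stand for less inhibition and higher numbers for more inhibition at the one dose given (going by the name of the read-out):
compound 1 `O=C(O)CCC(=O)/C=C/c1cn(-c2ccccc2)nc1-c1ccc(Cl)cc1`, 10.9%;
compound 2 `Cc1ccc(-c2nn(-c3ccccc3)cc2/C=C/C(=O)CCC(=O)O)cc1`, 6.25%;
compound 3 `NC(=O)c1ccccc1NC(=O)c1cn(-c2ccccc2)nc1-c1ccccc1`, 13.5%.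

Compound 3 holds the highest of the three numbers, yet its gaps to compound 1 and to compound 2 are both within the scatter, so no order among the three is established. Compound 4 `NC(=O)c1ccccc1NC(=O)c1cn(-c2ccccc2)nc1-c1ccc(Cl)cc1` differs from compound 3 by chloro in place of hydrogen on an aromatic carbon. Going by the values given here, the only measured step touching that ring, a number 4.7 percentage points lower from compound 1 to compound 2 (within the scatter), swaps methyl for chloro rather than hydrogen for chloro and stays within the scatter, so it bears on this change only loosely. A step of about a number 1.5 percentage points higher from compound 3 to compound 4 (within the scatter) is expected, in no direction beyond the scatter. Compound 4 is estimated at 15%, between 5% and 27%.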

Compound 4, a percentage reported as inhibition, in the whole organism at one dose (the size of the read-out at that dose, not a potency): 9.38%
The estimate for compound 4 lay 5.6 percentage points above the measured number, within the range that was stated.
By their numbers in this assay, from the lowest: compounds 2, 4, 1 and 3 (each within the scatter of the next).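

In this assay, phenyl to 4-chlorophenyl gives a number 4.1 percentage points lower from compound 3 to compound 4 (within the scatter), so chloro on this aromatic carbon, para to a large group, stays within the scatter of hydrogen. The earlier step at this place compared only methyl with chloro, whereas this pair gives a direct reading against hydrogen. No measured evidence bears on this result.

On these data alone, whether an amine or a methoxy group at this place would give a step beyond the scatter remains open. Also open, as far as these compounds go, is whether hydrogen and chloro read alike with the side chain of compound 1.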